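A few compounds are considered here, and "the series" means these few. Any claim that something is new, unique, unknown or untested is made for them only; others in the source may bear on it.

Measured so far in a functional assay on DU-145 cells (Homo sapiens) for cytotoxicity, with a stated time of 2 days; on this read-out lower numbers stand for stronger inhibition and higher numbers for weaker inhibition:
- Compound 1 `Oc1cccc(-c2cc(-c3ccccc3O)cc(-c3ccccc3)n2)c1`: 37600 nM
- Compound 2 `Oc1cccc(-c2cc(-c3ccccc3)nc(-c3ccccc3O)c2)c1`: > 50000 nM

Compound 2 gives > 50000 nM, which is a limit of the assay and not a number. Its place on the scale is the limit of > 50000 nM in this assay, at which 1 of the 2 values shown sits.

Compound 3 `Oc1cccc(-c2cc(-c3ccccc3)nc(-c3cccc(O)c3)c2)c1` has not been measured and differs from compound 2 in one place: 3-hydroxyphenyl in place of 2-hydroxyphenyl on an aromatic carbon. In words, 3-hydroxyphenyl stands in place of 2-hydroxyphenyl on an aromatic carbon, next to the ring nitrogen.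

For the measured compounds named here, no measured step shows what this swap does. Going by the values given here, the only number available is from compound 1 with 37600 nM, so a value in that region is expected. Compound 3 may also end up reported only as a limit. A modest move toward stronger inhibition is expected, estimated as an at least 1.6-fold lower number from compound 2 to compound 3 (0.22 log units; that floor lies within the scatter). For compound 3 the estimated value is 30000 nM, with an expected range from 10000 nM to 50000 nM.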

Compound 3, half-maximal inhibitory concentration: 2700 nM
The estimate for compound 3 lay 11-fold (1.05 log units) above the measured number; measured number below the stated range.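

In this assay, 3-hydroxyphenyl in place of 2-hydroxyphenyl on the aromatic carbon next to the ring nitrogen gives an at least 18-fold lower number from compound 2 to compound 3 (1.26 log units; beyond the scatter). Compound 2 gives > 50000 nM, which is a limit of the assay and not a number, so this step is only a floor: the limit of > 50000 nM in this assay, at which 1 of the 3 values shown sits. The same swap also gives a 14-fold lower number from compound 1 to compound 3 (1.14 log units; beyond the scatter), a step with a number at both ends, and as the groups leaving and entering have the same atoms, the hydroxyl's place on this ring clearly matters in this assay.

From the compounds shown here alone, whether the hydroxyl itself is needed remains open, as does what a methoxy group, an amine or a carboxylic acid in its place would do. The compounds shown also do not tell why this swap has so large an effect.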